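Chloro on the Sulfonyl Ring in Two Pyrazole Benzamide Pairs

A few compounds are considered here, and "the series" means these few. Any claim that something is new, unique, unknown or untested is made for them only; others in the source may bear on it.

Measured so far:
- Compound 1, `COc1cccc(-n2cc(NC(=O)c3cccc(NS(=O)(=O)c4ccccc4)c3)cn2)c1`: 25000 nM
- Compound 2, `COc1cccc(-n2cc(NC(=O)c3cccc(NS(=O)(=O)c4ccc(Cl)cc4)c3)cn2)c1`: 19600 nM
- Compound 3, `Cc1ccc(-n2cc(NC(=O)c3ccc(NS(=O)(=O)c4ccccc4)cc3)cn2)cc1`: 18100 nM

All three were tested in a functional assay on HepG2 cells (Homo sapiens) for inhibition, read by MTT assay, with a stated time of 48 h; on this read-out higher numbers stand for weaker inhibition and lower numbers for stronger inhibition. Compound 1 and compound 2 share one core and differ only in one spot, (chloro in place of hydrogen on an aromatic carbon). The step of a 1.3-fold lower number from compound 1 to compound 2 (0.11 log units; within the scatter) shows that this change did not move the number beyond what repeated measurements of the same compound would show.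

Compound 3 rests on a different core; how that core differs from the core of compound 1 is not broken down here. The values of compound 1 and compound 3 lie within the scatter of each other, so they cannot be ordered.

Compound 4, `Cc1ccc(-n2cc(NC(=O)c3ccc(NS(=O)(=O)c4ccc(Cl)cc4)cc3)cn2)cc1`, has not yet been measured. It stands to compound 3 as compound 2 stands to compound 1: chloro in place of hydrogen on an aromatic carbon. The place of the change is described in the same words in both pairs, so this is the same change, made on a second core.

Since the only shown instance of this change gave a 1.3-fold lower number from compound 1 to compound 2 (0.11 log units; within the scatter), a step of similar size is expected here, a 1.2-fold lower number from compound 3 to compound 4 (0.08 log units; within the scatter). Because compound 3 gives 18100 nM, compound 4 is estimated at 15000 nM, most likely between 7000 nM and 32000 nM, with the caution that a single earlier pair on another core is a thin basis.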

Compound 4, half-maximal inhibitory concentration: 9720 nM
The estimate for compound 4 lay 1.5-fold (0.19 log units) above the measured number; the range from low to high includes it.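

In this assay, replacing hydrogen with chloro turns the phenylsulfonyl group into a (4-chlorophenyl)sulfonyl group and gives a 1.9-fold lower number from compound 3 to compound 4 (0.27 log units; within the scatter), so on this second core the change again cannot be told apart from the differences seen when one compound is simply measured again. Set side by side, the two steps show no sign that the change behaves differently on the two cores: the same change on two cores in this assay, a 1.3-fold lower number (0.11 log units; within the scatter) from compound 1 to compound 2 and a 1.9-fold lower number (0.27 log units; within the scatter) from compound 3 to compound 4, 1.5-fold (0.16 log units) apart, within the scatter of two such steps. This means the result carries over in a modest sense, as both pairs give a step within the scatter, but it does not show that chloro truly strengthens inhibition on either core, and two pairs are too few to set a rule for the series.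

At this spot on the sulfonyl ring, the compounds shown carry only hydrogen or chloro, so it remains open whether a different group there, such as a nitrile, an amine or a carboxylic acid, would give a step beyond the scatter on either core. Going by these compounds, it also remains open whether the chloro step would look the same on cores other than these two, or in a cell line other than the one used here.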